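This account rests on a few compounds, and the source may have more. Where it says the series, first, only, none or still open, it means among the compounds named here.

Measured in an ADME assay for pharmacokinetics, at pH 7.4; on this read-out higher numbers stand for a longer-lived compound and lower numbers for a shorter-lived compound:
- Compound 1 `COc1cnc(C[S+]([O-])c2nc3cc(OC(F)F)ccc3[nH]2)cc1OC`: > 200 h, a limit of the assay and not a number
- Compound 2 `COc1cnc(C[S+]([O-])c2nc3cc(OC(F)F)ccc3[nH]2)c(C)c1OC`: 60 h
- Compound 3 `COc1ccnc(C[S+]([O-])c2nc3cc(OC(F)F)ccc3[nH]2)c1`: 51 h

Compound 1 stands at the limit of > 200 h in this assay, at which 1 of the 3 values shown sits. The other two compounds each differ from it in one place, and both steps lie beyond the scatter. One is an at least 3.3-fold lower number from compound 1 to compound 2 (0.52 log units; beyond the scatter), with methyl in place of hydrogen on an aromatic carbon. The other is an at least 3.9-fold lower number from compound 1 to compound 3 (0.59 log units; beyond the scatter), with hydrogen in place of methoxy on an aromatic carbon.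

Compound 4 `COc1cnc(C[S+]([O-])c2nc3cc(OC(F)(F)C(F)F)ccc3[nH]2)cc1OC` has not yet been measured. It differs from compound 1 by difluoromethyl in place of hydrogen on a saturated chain carbon bound to two fluorine atoms and an oxygen on an aromatic ring, turning difluoromethoxy into 1,1,2,2-tetrafluoroethoxy. Both measured steps are changes on an aromatic carbon, whereas this one falls on a saturated chain carbon bound to two fluorine atoms and an oxygen on an aromatic ring. Neither step therefore measures the new change directly, and their size cannot simply be carried over. Among the compounds with values here, with no measured step at this place, no shift beyond the scatter is expected in this assay. The expected step is a number no higher from compound 1 to compound 4 (the limit leaves the size open). The estimate starts from compound 1 and its > 200 h, which is a limit. Compound 4 is estimated at 200 h, with an expected range from 70 h to 600 h.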

Compound 4, half-life: 140 h
Beside the measured number, compound 4's estimate is 1.4-fold (0.15 log units) above it; low and high end bracket the measured number.
By their numbers in this assay, from the lowest: compounds 3 and 2 (each within the scatter of the next); then compound 4. At a limit, above all of these: compound 1.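

Within the data shown here, the earlier compounds changed only aromatic carbons, and compound 4 is the first to show how this assay responds to a change on the saturated chain carbon, with difluoromethoxy turned into 1,1,2,2-tetrafluoroethoxy: the step is an at least 1.4-fold lower number from compound 1 to compound 4 (0.15 log units; that floor lies within the scatter). Since that floor lies within the scatter, it does not by itself establish a real loss at this position, nor does it rule one out, and a larger drop remains possible. The value of compound 1 is a limit and not a number, and the true size of the step cannot be read because the comparison starts from that limit: the limit of > 200 h in this assay, at which 1 of the 4 values shown sits.

The compounds shown leave open how this assay would respond to other groups at this place, such as a plain methoxy, a trifluoromethoxy or a longer perfluorinated chain. They also leave open whether 1,1,2,2-tetrafluoroethoxy would give a similar step on the cores of compound 2 and compound 3, where the changes on the aromatic carbons are already in place.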